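Methyl in Place of Hydrogen on a Diaryl Urea

A few compounds are considered here, and "the series" means these few. Any claim that something is new, unique, unknown or untested is made for them only; others in the source may bear on it.

Compound 1 `O=C(Nc1ccccc1)Nc1ccc(Oc2ccc(-c3nccs3)cc2)cc1` has no result in a functional assay on A549 cells (Homo sapiens) for inhibition, read by MTT assay and WST assay, with a stated time of 72 h, tested at 10 uM (on this read-out lower numbers stand for less inhibition of growth and higher numbers for more inhibition of growth at the one concentration tested), recorded as "not determined" (no result reported), so its standing cannot be given in numbers. Compound 2 `O=C(Nc1ccc(Oc2ccc(-c3nccs3)cc2)cc1)Nc1ccc(Cl)c([N+](=O)[O-])c1`, a related urea, gives 77.1% in this assay. Compound 3 `Cc1ccc(NC(=O)Nc2ccc(Oc3ccc(-c4nccs4)cc3)cc2)cc1` differs from compound 1 by a single change: methyl in place of hydrogen on an aromatic carbon. For a change this small, no shift beyond the usual scatter of this assay is expected between compound 1 and compound 3, yet with no number for compound 1 the direction cannot be anchored. Compound 3 is estimated to reach 55% in this assay, within 25% to 85%.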

Compound 3, percent growth inhibition at one concentration: 15.6%
For compound 3 the middle estimate is 39.4 percentage points above the measured one; measured number outside the range, below it.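

In this assay the swap of group on the amide-type nitrogen gives a number 61.5 percentage points lower from compound 2 to compound 3 (beyond the scatter) so what this ring carries clearly matters for growth inhibition at the one concentration tested. The step for methyl alone cannot be read, as compound 1 has no number. Nothing measured here explains the drop.

Still open, on these data alone, is whether the chloro group, the nitro group or both carry the higher number of compound 2. An amine or a carboxylic acid at the place of the methyl in compound 3 would also be untested ground in the compounds shown.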